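The source may report more compounds than this note shows. Statements on the series, on what has been measured and on what is new or still open speak of the compounds shown alone.

Values in an ADME assay on BJ cells (Homo sapiens) for cytotoxicity, with a stated time of 72 h (on this read-out lower numbers stand for an effect already at smaller amounts and higher numbers for an effect only at larger amounts of compound), are as follows.

Compound 1 (`COc1ccc(/C=C/[C@@](C)(/C=C/c2ccc(O)c(/C=C/C#N)c2)CCC=C(C)C)cc1`) gives > 23700 nM
Compound 2 (`CCOC(=O)/C(C)=C/c1cc(/C=C/[C@](C)(/C=C/c2ccc(OC)cc2)CCC=C(C)C)ccc1O`) gives > 36600 nM
Compound 3 (`COc1ccc(/C=C/[C@@](C)(/C=C/c2ccc(O)c(/C=C/C(=O)OCc3ccccc3)c2)CCC=C(C)C)cc1`) gives > 36600 nM

Each of these entries is a limit and not a number. Compound 3 stands at a limit (> 36600 nM), and it is one of the compounds at the limit of > 36600 nM in this assay, at which 2 of the 3 values shown sit, so no number places it.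

Compound 4 (`COc1ccc(/C=C/[C@@](C)(/C=C/c2ccc(O)c(/C=C/C(C)=O)c2)CCC=C(C)C)cc1`) has methyl in place of benzyloxy on a carbonyl carbon, which reads as 2-(benzyloxycarbonyl)ethenyl to 2-acetylethenyl.

The nearest measured change is a step that the two limits leave unreadable from compound 1 to compound 3, with benzyloxycarbonyl in place of cyano on a double-bonded chain carbon bound to a double-bonded chain carbon. Also relevant is a step that the two limits leave unreadable from compound 2 to compound 3, with 2-(benzyloxycarbonyl)ethenyl in place of 2-(ethoxycarbonyl)prop-1-en-1-yl on an aromatic carbon. Among the measured compounds shown here, neither step has a readable size, but no compound in either pair gave a number in this assay.

Given those two steps, no change beyond the scatter is expected, in either direction, and the reading for compound 4 is expected to be a limit again. The expected move is an at least 1.0-fold lower number from compound 3 to compound 4 (0.00 log units; that floor lies within the scatter). For compound 4 the estimate is 36000 nM, with an expected range from 15000 nM to 80000 nM.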

Compound 4, half-maximal effective concentration: 12300 nM
Beside the measured number, compound 4's estimate is 2.9-fold (0.47 log units) above it; the whole stated range lies above it.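

With methyl in place of benzyloxy on a carbonyl carbon, this assay shows an at least 2.9-fold lower number from compound 3 to compound 4 (0.47 log units; beyond the scatter), the first readable change at this position, whereas the steps among compounds 1, 2 and 3 cannot be read, and this size is only a floor, as compound 3 stands at a limit: the limit of > 36600 nM in this assay, at which 2 of the 4 values shown sit.

Putting 2-acetylethenyl in place of 2-(ethoxycarbonyl)prop-1-en-1-yl on an aromatic carbon gives a floor of the same size, an at least 2.9-fold lower number from compound 2 to compound 4 (0.47 log units; beyond the scatter), so both esters shown at the higher limit separate from the acetyl compound. Acetyl in place of cyano is less clear, with an at least 1.9-fold lower number from compound 1 to compound 4 (0.28 log units; that floor lies within the scatter), a floor within the scatter that leaves open whether the acetyl compound truly differs from the nitrile compound, which stands at a lower limit: the limit of > 23700 nM in this assay, at which 1 of the 4 values shown sits.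

On these data alone, the true size of each step remains open, since only compound 4 has a number in this assay. As far as these compounds go, it is also open whether a carboxylic acid or a primary amide on the same carbonyl carbon would give a number, and how such a number would compare with that of the acetyl group.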